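The source may report more compounds than this note shows. Statements on the series, on what has been measured and on what is new or still open speak of the compounds shown alone.

Working notes on the series. Compound 1 `O=C(O)CCCCCCN1C(=O)CC[C@@H]1CC[C@@H](O)CCc1ccccc1` carries its acid on a saturated chain and a plain phenyl at the far end of the hydroxylated side chain; in an assay on HEK293 cells for binding affinity to prostaglandin E2 receptor EP4 subtype (Rattus norvegicus) (a higher number here means a weaker inhibitor, a lower number a stronger inhibitor), compound 1 gives 2710 nM. Compound 2 `O=C(O)c1ccc(CCCN2C(=O)CC[C@@H]2CCC(O)Cc2ccc3ccccc3c2)s1` and compound 3 `O=C(O)c1ccc(CCCN2C(=O)CC[C@@H]2CC[C@@H](O)Cc2ccc(F)cc2)s1` share a different acid-bearing part and differ from each other only at the aromatic end of the side chain. In this assay compound 2 gives 65 nM, and compound 3 gives 70 nM.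

Where compound 3 stands: its number is the second highest of the three, but it sits so close to compound 2 that the two lie within the usual scatter of each other, so no order between them can be read. Compound 1 lies far above compound 3, a gap well beyond the scatter.

Compound 4 `O=C(O)c1ccc(CCCN2C(=O)CC[C@@H]2CC[C@@H](O)Cc2cccc(Cl)c2)s1` is the next member: 3-chlorophenyl in place of 4-fluorophenyl on a saturated chain carbon, two bonds along the chain from an oxygen on a saturated carbon. Going by the values given here, no pair of measured compounds shows this particular exchange, so its size is unknown. Compounds 2 and 3 show that two rather different aromatic ends give near-identical numbers on the shared acid-bearing part, so the expectation for compound 4 is a change of no more than the scatter, with no clear direction. Compound 4 is therefore estimated at 80 nM, within 30 nM to 250 nM, an expected step of a 1.1-fold higher number from compound 3 to compound 4 (0.06 log units; within the scatter).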

Compound 4, half-maximal inhibitory concentration: 1.1 nM
Estimate against measurement, compound 4: 73-fold (1.86 log units) above; the whole stated range lies above it.
By their numbers in this assay, from the lowest: compound 4; then compounds 2 and 3 (each within the scatter of the next); then compound 1.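

In this assay, 3-chlorophenyl in place of 4-fluorophenyl on a saturated chain carbon, two bonds along the chain from an oxygen on a saturated carbon, gives a 64-fold lower number from compound 3 to compound 4 (1.80 log units; beyond the scatter), so the number at this position can respond strongly to a change in the aromatic end. The two groups match in heavy-atom count, hydrogen-bond donors, hydrogen-bond acceptors and net charge, so none of these counts separates them, and the step arises from an exchange of halogen and ring position alone. Nothing at hand bears on why the step is this large.

The compounds shown leave open whether the step follows the chlorine or its ring position, a question that 4-chlorophenyl and 3-fluorophenyl at the same chain carbon would separate. Also open, going by these compounds, are whether 3-bromophenyl or 3-methoxyphenyl would behave like 3-chlorophenyl here, and whether 3-chlorophenyl would bring a similar step on the saturated acid-bearing chain of compound 1.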